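From Ethylamino to Propylamino on a Shared Core

The compounds below may be only part of what the source reports. "The series", "measured", "known", "first", "only" and "open" are said of these compounds alone.

Going by the values given here, compound 1 `CC(=O)Nc1c(C)nc2c(OCc3ccccc3)cccn12` gives 44% in a functional assay on the whole organism with Canis familiaris (Canis lupus familiaris) as the target, at a dose of 8 mg/kg by the oral route (on this read-out higher numbers stand for a stronger effect at the one dose given and lower numbers for a weaker effect), and compound 2 `CCNc1c(C)nc2c(OCc3ccccc3)cccn12` gives 68%, the higher of the two numbers measured so far. Among the compounds with values here, the single step in hand, a number 24 percentage points higher from compound 1 to compound 2 (beyond the scatter), concerns ethyl in place of acetyl on a nitrogen on an aromatic ring. Compound 3 `CCCNc1c(C)nc2c(OCc3ccccc3)cccn12` differs from compound 2 by methyl in place of hydrogen on a saturated chain carbon, two bonds along the chain from a nitrogen on an aromatic ring. Within the data shown here, no measured pair shows ethylamino to propylamino, so the one known step is only a loose guide here. Compound 3 is therefore expected to give 65%, between 45% and 85%. The expected step of a number 3 percentage points lower from compound 2 to compound 3 (within the scatter) is small, within the scatter.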

Compound 3, a percentage reported as inhibition, in the whole organism at one dose (the size of the read-out at that dose, not a potency): 68%
Compound 3: middle estimate off by 3 percentage points, on the low side, within the range that was stated.
By their numbers in this assay, from the lowest: compound 1; then compounds 2 and 3 (each within the scatter of the next).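

The step from ethylamino to propylamino reads no change at the digits printed from compound 2 to compound 3 (within the scatter) in this assay and shows that this nitrogen carries the longer chain with no change beyond the scatter. The step of a number 24 percentage points higher from compound 1 to compound 3 (beyond the scatter) shows that the rise over the acetyl group is not confined to ethyl, as propyl gives a rise as well. Nothing available explains why the extra methyl leaves the read-out unchanged. Going by these compounds, whether a butyl chain, a branched isopropyl group or an unsubstituted amine on this nitrogen would hold the same level remains open.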